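Swapping the amide-bound ring in a lipophilicity series

This account rests on a few compounds, and the source may have more. Where it says the series, first, only, none or still open, it means among the compounds named here.

Measured so far:
- compound 1, `NCc1csc(NC(=O)c2cc3ccccc3[nH]2)n1`: 1.4
- compound 2, `CC(C)(C)c1cc(C(=O)Nc2ccncc2)n(Cc2ccccc2)n1`: 4
- compound 3, `NCc1csc(NC(=O)c2ccon2)n1`: -0.1

These three were read in a physicochemical assay for lipophilicity, read by HPLC, at pH 7.4; on this read-out higher numbers stand for higher lipophilicity and lower numbers for lower lipophilicity. Compound 2 gives the highest number of the three; compound 1 lies well below it and compound 3 lower still, both gaps beyond the scatter. Compound 4, `CC(C)(C)c1cc(C(=O)Nc2nc(CO)cs2)n(Cc2ccccc2)n1`, has not yet been measured. It differs from compound 2 in one place: 4-(hydroxymethyl)-1,3-thiazol-2-yl in place of pyridin-4-yl on an amide-type nitrogen. For the measured compounds named here, no measured pair shows this exact change, so the expected step rests on the new group's make-up. Compound 4 is expected to come in somewhat lower, with a step of a number 0.80 log units lower from compound 2 to compound 4 (beyond the scatter) in this assay. Because compound 2 stands at 4, compound 4 is estimated at 3.2, within 2.5 to 3.9.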

Compound 4, distribution coefficient: 3.4
The estimate for compound 4 lay 0.20 log units below the measured number; the range from low to high includes it.
By their numbers in this assay, from the lowest: compound 3; then compound 1; then compound 4; then compound 2.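

In this assay, for the compounds shown here, the swap of pyridin-4-yl for 4-(hydroxymethyl)-1,3-thiazol-2-yl on the amide-type nitrogen gives a number 0.60 log units lower from compound 2 to compound 4 (beyond the scatter) and is the first change here seen in one place alone. This shows that the number responds to the group at this position, though this one swap changes both the ring and its hydroxymethyl group. Nothing measured here accounts for the size of the step.

On these data alone, how much of the step belongs to the ring and how much to the hydroxymethyl group stays open. A methyl or a carboxylic acid in its place on the same ring would be needed to separate the two.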